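Ring-amine substituent variation: ethyl to thiophen-3-yl

The source may hold more compounds than are shown below. What is called first, only, known or untested is meant among the compounds shown, and "the series" means these compounds.

The series shares one core and differs only on a saturated chain carbon bound to an amine nitrogen in a ring; all members are read in a functional assay on the whole organism for antagonist activity, with Mus musculus as the target; a lower number here means that less compound is needed, a higher number that more compound is needed for the effect. Compound 1 `COc1cc(N)c(Cl)cc1NC(=O)C1CCN(Cc2cccc(C)c2)CC1` carries 3-methylphenyl there and gives 2.4 mg/kg. Compound 3 `COc1cc(N)c(Cl)cc1NC(=O)C1CCN(CC2CCCCC2)CC1` carries cyclohexyl and gives 2.9 mg/kg; the two stand within the scatter of each other, as a 1.2-fold higher number from compound 1 to compound 3 (0.08 log units; within the scatter) shows. Compound 2 `CCCN1CCC(C(=O)Nc2cc(Cl)c(N)cc2OC)CC1` carries ethyl and stands apart. For compound 2 the result is only a limit of the assay, > 10 mg/kg, so no number is known for it (the limit of > 10 mg/kg in this assay, at which 1 of the 3 values shown sits). Compound 4 `COc1cc(N)c(Cl)cc1NC(=O)C1CCN(Cc2ccsc2)CC1` is the unmeasured member: thiophen-3-yl in place of ethyl on a saturated chain carbon bound to an amine nitrogen in a ring.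

Within the data shown here, two measured steps bear on this change, both leaving ethyl. The step of an at least 4.1-fold higher number from compound 1 to compound 2 (0.61 log units; beyond the scatter) and the step of an at least 3.4-fold lower number from compound 2 to compound 3 (0.53 log units; beyond the scatter) show that exchanging ethyl for a substituent with a ring lowers the number in this assay by at least a modest amount. Thiophen-3-yl is a further ring substituent, so a downward step from compound 2 is expected for compound 4, at least modest in size. Compound 4 is therefore expected at 3 mg/kg, within 1.5 mg/kg to 7 mg/kg. This estimate means an expected step of an at least 3.3-fold lower number from compound 2 to compound 4 (0.52 log units; beyond the scatter), in the direction the measured steps point.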

Compound 4, dose for half-maximal effect: 3.4 mg/kg
Beside the measured number, compound 4's estimate is 1.1-fold (0.05 log units) below it; the measured number falls inside the stated range.
By their numbers in this assay, from the lowest: compounds 1, 3 and 4 (each within the scatter of the next). At a limit, above all of these: compound 2.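

Thiophen-3-yl joins 3-methylphenyl and cyclohexyl as a third ring substituent on a saturated chain carbon bound to an amine nitrogen in a ring, and leaving ethyl for it in this assay gives an at least 2.9-fold lower number from compound 2 to compound 4 (0.46 log units; beyond the scatter). Against the other two ring substituents, the same change gives a 1.2-fold higher number from compound 3 to compound 4 (0.07 log units; within the scatter) and a 1.4-fold higher number from compound 1 to compound 4 (0.15 log units; within the scatter), so the read-out does not separate compound 4 from compound 3 or compound 1. Within these compounds, the five-membered aromatic ring with its sulfur and its hydrogen-bond acceptor therefore leaves no visible mark beyond what 3-methylphenyl and cyclohexyl already show, and compound 2 remains the only member set apart.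

Compound 2 stands at a limit and not at a number, so the full size of the step away from ethyl stays open: the limit of > 10 mg/kg in this assay, at which 1 of the 4 values shown sits.

Also open, going by these compounds, is whether a ring is needed at this place or whether the larger group alone is enough; a longer chain such as hexyl, or a ring carrying an amine or a carboxylic acid, would test how far this tolerance extends.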